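The source may report more compounds than this note shows. Statements on the series, on what has been measured and on what is new or still open speak of the compounds shown alone.

In a functional assay on MCF7 cells (Homo sapiens) for cytotoxicity, read by MTT assay, with a stated time of 4 days (on this read-out lower numbers stand for stronger inhibition and higher numbers for weaker inhibition), compound 2 `C=C1C[C@]23C[C@@]1(O)CC[C@H]2c1ccc(OS(=O)(=O)c2ccc(C)cc2)c(C)c1[C@@H]3Cn1cc(-c2ccc(C)cc2)nn1` gives > 20000 nM, which is a limit of the assay rather than a number. Compound 3 `C=C1C[C@]23C[C@@]1(O)CC[C@H]2c1ccc(OS(=O)(=O)c2ccc(C)cc2)c(C)c1[C@@H]3Cn1cc(-c2ccc(F)cc2)nn1` in this assay gives > 20000 nM, again a limit. Compound 1 `C=C1C[C@]23C[C@@]1(O)CC[C@H]2c1cc(Br)c(O)c(C)c1[C@@H]3Cn1cc(-c2ccc(C)cc2)nn1` in this assay gives > 20000 nM, once more a limit. The step from compound 2 to compound 3 is therefore a step that the two limits leave unreadable from compound 2 to compound 3, and the limit of > 20000 nM in this assay, at which 3 of the 3 values shown sit, accounts for that. Compound 4 `C=C1C[C@]23C[C@@]1(O)CC[C@H]2c1ccc(O)c(C)c1[C@@H]3Cn1cc(-c2ccc(C)cc2)nn1` differs from compound 2 in one place: hydrogen in place of (4-methylphenyl)sulfonyl on an oxygen on an aromatic ring. For the measured compounds named here, no measured step covers this change, and the only step touching compound 2 cannot be read in size. Compound 4 is accordingly expected to sit near the same limit, with an estimated 25000 nM in this assay (range 8000 nM to 80000 nM). The expected step is a step that the limit leaves unreadable from compound 2 to compound 4.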

Compound 4, half-maximal inhibitory concentration: > 20000 nM
Compound 4: a limit, no number; the forecaster's own chance of this, stated with the estimate: 75%; the middle value does not contradict the limit.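

In this assay compound 4 gives > 20000 nM, a limit of the assay, so its steps from compound 2 and from compound 1 cannot be read in size: the limit of > 20000 nM in this assay, at which 4 of the 4 values shown sit.

The compounds shown leave open how far removing the (4-methylphenyl)sulfonyl or bromo group shifts the true values, since none of them gives a number.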